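The source may hold more compounds than are shown below. What is called first, only, known or untested is meant among the compounds shown, and "the series" means these compounds.

Values measured in an ADME assay on HEK293 cells (Homo sapiens) for cytotoxicity, with a stated time of 72 h (a lower number here means that less compound is needed, a higher number that more compound is needed for the effect), are these
- compound 1 `Cc1ccc(-c2nc3ccccc3s2)cc1NC(=O)c1cc([N+](=O)[O-])c(N(C)C)cc1Cl` gives > 25000 nM (a limit)
- compound 2 `COC(=O)C1CCN(c2cc(Cl)c(C(=O)Nc3cc(-c4nc5ccccc5s4)ccc3C)cc2[N+](=O)[O-])CC1` gives > 25000 nM (a limit)
- compound 3 `Cc1ccc(-c2nc3ccccc3s2)cc1NC(=O)c1cc([N+](=O)[O-])c(N2CCCCC2)cc1Cl` gives > 25000 nM (a limit)

Compound 2 has no exact number, only its limit (> 25000 nM), and the two other values are limits too (the limit of > 25000 nM in this assay, at which 3 of the 3 values shown sit). Compound 4 `COC(=O)C1CCN(c2cc(Cl)c(C(=O)Nc3cc(-c4nc5ccccc5s4)ccc3OC)cc2[N+](=O)[O-])CC1` carries methoxy in place of methyl on an aromatic carbon, para to a 1,3-benzothiazol-2-yl group (methoxy in place of methyl on an aromatic carbon). The measured steps all change a different group, so they bear on this change only loosely: a step that the two limits leave unreadable from compound 1 to compound 2 and a step that the two limits leave unreadable from compound 1 to compound 3 and also a step that the two limits leave unreadable from compound 2 to compound 3 have no readable size. With compound 2 itself a limit (> 25000 nM) and no readable step, no step beyond the scatter is expected in this assay, and another limit is the likeliest report. Written as an expected step, this gives (a number no higher from compound 2 to compound 4 (the limit leaves the size open)). For compound 4 the estimate is 25000 nM (expected range 10000 nM to 50000 nM).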

Compound 4, half-maximal effective concentration: > 25000 nM
Compound 4: a limit, no number; the forecaster's own chance of this, stated with the estimate: 85%; the middle value sits exactly at the limit.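

Going by these compounds alone, compound 2 and compound 4 each give only a limit in this assay, so no step from methyl to methoxy can be read between them. The compounds shown leave open what exact concentration any of them would need for the effect.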